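Butylamino on a quinone core: a predicted cytotoxicity shift

The source may report more compounds than this note shows. Statements on the series, on what has been measured and on what is new or still open speak of the compounds shown alone.

Measured compounds:
Compound 1, `CC1=CCC[C@H]2[C@](C)(CC3=CC(=O)C=CC3=O)[C@@H](C)CC[C@]12C` — 84000 nM
Compound 2, `CC(C)(C)C1=CC(=O)C=CC1=O` — > 100000 nM
Compound 3, `CCCCNC1=CC(=O)C(C(C)(C)C)=CC1=O` — 36000 nM

Three compounds were tested in a functional assay on NCI-H460 cells (Homo sapiens) for cytotoxicity, read by MTT assay, with a stated time of 72 h; on this read-out lower numbers stand for stronger inhibition and higher numbers for weaker inhibition. Compound 1 gives 84000 nM. Compound 3 gives 36000 nM. Compound 2 reaches only the limit of the assay, > 100000 nM, so no number is known for it; the relevant mark is the limit of > 100000 nM in this assay, at which 1 of the 3 values shown sits.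

Compound 3 arises from compound 2 by one change: butylamino in place of hydrogen on a double-bonded ring carbon. This change gave an at least 2.7-fold lower number from compound 2 to compound 3 (0.44 log units; beyond the scatter). Among the measured compounds, compound 1 has the highest number, and its nearest neighbour is compound 3.

Compound 4, `CCCCNC1=CC(=O)C=C(C[C@]2(C)[C@@H](C)CC[C@]3(C)C(C)=CCC[C@@H]23)C1=O`, has not yet been measured. It arises from compound 1 by butylamino in place of hydrogen on a double-bonded ring carbon. The difference between the core of compound 1 and the core of compound 2 is not broken down here. The two changes are the same kind of change but not the same: in compound 3 the butylamino sits three ring bonds from the ring atom that bears a tert-butyl group, whereas in compound 4 it sits two ring bonds from the ring atom that bears a large group.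

Resting on the step from compound 2 to compound 3 in this assay, an at least 2.7-fold lower number from compound 2 to compound 3 (0.44 log units; beyond the scatter), compound 4 is expected to show a step of about a 2.8-fold lower number from compound 1 to compound 4 (0.45 log units; beyond the scatter) from compound 1. Compound 4 is therefore estimated at 30000 nM, with a range from 10000 nM to 90000 nM.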

Compound 4, half-maximal inhibitory concentration: 16000 nM
Compound 4: the middle estimate sits 1.9-fold (0.27 log units) above what was measured; the range from low to high includes it.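

In this assay, butylamino in place of hydrogen on a double-bonded ring carbon gave a 5.3-fold lower number from compound 1 to compound 4 (0.72 log units; beyond the scatter), so on the core of compound 1 the change moved the number in the same direction as it did on the core of compound 2. Setting the two results side by side gives the following comparison: the same change on two cores in this assay, an at least 2.7-fold lower number (0.44 log units; beyond the scatter) from compound 2 to compound 3 and a 5.3-fold lower number (0.72 log units; beyond the scatter) from compound 1 to compound 4; the limit leaves it open whether they differ. Compound 2 gives > 100000 nM, which is a limit of the assay and not a number, so these two cases show a shared direction but not a shared size, and two cores are too few to establish a general rule.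

The compounds shown leave open whether the lower number depends on butylamino itself or would also appear with a shorter chain such as methylamino, a longer chain such as octylamino, or a ring amine such as morpholine. They also leave open how much the place of the group matters, since butylamino sits three ring bonds from the ring atom bearing the tert-butyl group in compound 3 but two ring bonds from the ring atom bearing the large group in compound 4.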